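This account rests on a few compounds, and the source may have more. Where it says the series, first, only, none or still open, it means among the compounds named here.

In an ADME assay on BHK cells (Mesocricetus auratus) for cytotoxicity, read by MTT assay, with a stated time of 96 h (a higher number here means that more compound is tolerated, a lower number that less compound is tolerated), compound 3 `Fc1ccc(NC(=S)Nc2cccc(C(F)(F)F)c2)cc1` gives 26000 nM. This lies within the scatter of compound 1 `FC(F)(F)c1cccc(NC(=S)Nc2ccccc2)c1` at 41000 nM, but higher, beyond the scatter, than compound 2 `O=C(NC(=S)Nc1cccc(C(F)(F)F)c1)[C@H]1C[C@@H]2CC[C@H]1C2` at 9600 nM. Compound 4 `CC(=O)NC(=S)Nc1cccc(C(F)(F)F)c1` has acetyl in place of 4-fluorophenyl on an amide-type nitrogen. Within the data shown here, the only measured step, a 1.6-fold lower number from compound 1 to compound 3 (0.20 log units; within the scatter), involves a fluoro in place of hydrogen on an aromatic carbon, so it bears only loosely on this change. Closer is compound 2, which also carries a carbonyl-bearing group on an amide-type nitrogen and gives 9600 nM. A slightly lower number, not beyond the scatter, is therefore expected in this assay: a 1.5-fold lower number from compound 3 to compound 4 (0.18 log units; within the scatter). Compound 4 is estimated at 17000 nM, within a range from 7000 nM to 45000 nM.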

Compound 4, half-maximal cytotoxic concentration: > 100000 nM
Compound 4: only a limit was reported; the forecaster's own chance of this, stated with the estimate: 10%; middle value at least 5.8-fold (0.76 log units) away from the limit.
By their numbers in this assay, from the lowest: compound 2; then compounds 3 and 1 (each within the scatter of the next). At a limit, above all of these: compound 4.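

Compound 4 stands at a limit of this assay, not at a number: the limit of > 100000 nM in this assay, at which 1 of the 4 values shown sits. On this amide-type nitrogen, acetyl in place of 4-fluorophenyl brings an at least 3.8-fold higher number from compound 3 to compound 4 (0.58 log units; beyond the scatter), and acetyl in place of phenyl brings an at least 2.4-fold higher number from compound 1 to compound 4 (0.38 log units; beyond the scatter). A carbonyl on this nitrogen does not settle the outcome alone, since replacing the group of 7 heavy atoms on the carbonyl carbon with one carbon atom gives an at least 10-fold higher number from compound 2 to compound 4 (1.01 log units; beyond the scatter). The compounds shown leave open whether a longer chain on that carbonyl carbon, or an amine in place of acetyl, would also reach such a limit.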